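Amide side chain change from compound 3 to compound 4

The compounds below may be only part of what the source reports. "The series", "measured", "known", "first", "only" and "open" are said of these compounds alone.

Measured in a functional assay on SAS cells (Homo sapiens) for cytotoxicity, read by MTT assay, with a stated time of 48 h; on this read-out lower numbers stand for stronger inhibition and higher numbers for weaker inhibition:
- compound 1 `COC(=O)CNC(=O)CSC1=CC(=O)c2cccc(OC)c2C1=O`: > 100000 nM, a limit of the assay
- compound 2 `CC[C@H](C)[C@H](NC(=O)CSC1=C(OC)C(=O)c2ccccc2C1=O)C(=O)OC`: 60000 nM
- compound 3 `COC(=O)[C@H](CC(C)C)NC(=O)CSC1=C(OC)C(=O)c2ccccc2C1=O`: 25500 nM

Compound 3 holds the lowest of the two actual numbers. Compound 4 `COC(=O)CCCNC(=O)CSC1=C(OC)C(=O)c2ccccc2C1=O` is unmeasured and has 3-(methoxycarbonyl)propyl in place of 1-(methoxycarbonyl)-3-methylbutyl on an amide-type nitrogen. Among the measured compounds shown here, the one measured step on this side chain is a 2.4-fold lower number from compound 2 to compound 3 (0.37 log units; beyond the scatter). On that basis, a modest move towards a higher number is expected in this assay. The upper limit stays in view: the limit of > 100000 nM in this assay, at which 1 of the 3 values shown sits. The estimated step is a 1.8-fold higher number from compound 3 to compound 4 (0.25 log units; within the scatter). For compound 4 the expected value is 45000 nM, with an estimated range of 15000 nM to 100000 nM.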

Compound 4, half-maximal inhibitory concentration: 24500 nM
Compound 4: the middle estimate sits 1.8-fold (0.26 log units) above what was measured; the measured number falls inside the stated range.
By their numbers in this assay, from the lowest: compounds 4 and 3 (each within the scatter of the next); then compound 2. At a limit, above all of these: compound 1.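

On the amide-type nitrogen, 3-(methoxycarbonyl)propyl stands level with 1-(methoxycarbonyl)-3-methylbutyl in this assay with a 1.0-fold lower number from compound 3 to compound 4 (0.02 log units; within the scatter) and thus without the defined stereocentre. The same group gives a 2.4-fold lower number from compound 2 to compound 4 (0.39 log units; beyond the scatter) so that 1-(methoxycarbonyl)-2-methylbutyl alone keeps the higher number among these three side chains. Nothing available gives a cause for either step.

Still open, going by these compounds, is whether a carboxylic acid in place of the methyl ester, or a longer chain on the same nitrogen, would shift the number.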